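Carboxamide in place of the propenyloxy group on compound 1

The source may report more compounds than this note shows. Statements on the series, on what has been measured and on what is new or still open speak of the compounds shown alone.

Compound 1 `C/C=C\Oc1cncc(N2CCCNCC2)c1`: 1.29 nM
Compound 2 `Brc1cncc(N2CCCNCCC2)c1`: 2.82 nM
Compound 3 `C=COc1cc(N2CCCNCC2)cnc1Br`: 0.646 nM

Three compounds that share a pyridine bearing a seven-membered diamine have been measured in an assay on HEK293 cells for displacement of a labelled ligand from Neuronal acetylcholine receptor; alpha4/beta2 (Homo sapiens); on this read-out lower numbers stand for stronger inhibition and higher numbers for weaker inhibition. Compound 1 gives 1.29 nM and holds the second highest of the three numbers. Compound 3 gives 0.646 nM, a number within the scatter of compound 1, so no order between these two can be read. Compound 2 gives 2.82 nM, a number beyond the scatter from compound 1.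

Compound 4 `NC(=O)c1cncc(N2CCCNCC2)c1` has not yet been measured. It differs from compound 1 in one place: a group of 3 heavy atoms (1 carbon, 1 nitrogen, 1 oxygen; no ring) in place of a group of 4 heavy atoms (3 carbon, 1 oxygen; no ring), on an aromatic carbon. Among the measured compounds shown here, no step between two measured compounds covers this kind of change, so its size can only be guessed. The measured compounds show that a bromine or an unsaturated ether on this aromatic carbon all keep the number low. Compound 4 is expected to give a somewhat higher number, with a step of a 3.9-fold higher number from compound 1 to compound 4 (0.59 log units; beyond the scatter) beyond the scatter. The estimate for compound 4 is 5 nM, between 1 nM and 30 nM.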

Compound 4, half-maximal inhibitory concentration: 20 nM
Compound 4: middle estimate off by 4.0-fold (0.60 log units), on the low side, within the range that was stated.
By their numbers in this assay, from the lowest: compounds 3 and 1 (each within the scatter of the next); then compound 2; then compound 4.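

In this assay, this aromatic carbon, two atoms from the ring nitrogen, proves sensitive to the group it carries: carbamoyl in place of the propenyloxy group brings a 16-fold higher number from compound 1 to compound 4 (1.19 log units; beyond the scatter). The change is small by the counts, with 3 heavy atoms entering for 4 and a double bond outside the ring and a hydrogen-bond acceptor on each side, while the entering group adds a hydrogen-bond donor. No measurement shown accounts for the size of this step.

Going by these compounds, whether the amide hydrogen or some other feature of the carbamoyl group goes with the higher number stays open, since a nitrile, a methyl ketone or a methyl-substituted amide on this carbon would be needed to separate them. A carboxylic acid, an amine or a longer ether chain here also remains unexplored in the compounds shown.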